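The source may hold more compounds than are shown below. What is called first, only, known or untested is meant among the compounds shown, and "the series" means these compounds.

Measured compounds: compound 1 `CCN(c1nc(Cl)nc(N[C@H](C)c2ccccc2)n1)C(C)C` gives 52500 nM; compound 2 `CNc1nc(Cl)nc(N[C@H](C)c2ccccc2)n1` gives 562 nM; compound 3 `CC(C)Nc1nc(Cl)nc(N[C@H](C)c2ccccc2)n1` gives 2000 nM, all in an ADME assay on the whole organism for inhibition, with Echinochloa crus-galli var. formosensis as the target, with a stated time of 4 days; a higher number here means a weaker inhibitor, a lower number a stronger inhibitor.

Compound 1 holds the highest number of the three in this assay, with a 26-fold lower number from compound 1 to compound 3 (1.42 log units; beyond the scatter) and a 93-fold lower number from compound 1 to compound 2 (1.97 log units; beyond the scatter). Compound 4 `CCN(c1nc(Cl)nc(N[C@@H](C)c2ccccc2)n1)C(C)C` keeps every atom and bond of compound 1 and differs only in configuration: the two compounds have the same atoms and bonds and differ only in configuration as drawn: 1 of 1 stereo elements differ; a stereocentre at a saturated chain carbon is drawn R in compound 1 and S in compound 4. Within the data shown here, none of the measured steps touches configuration; each of them alters the amino substituent on the shared core, so no measured step bears directly on this change, and the data give no ground for a direction. The step is therefore expected to be a 1.8-fold lower number from compound 1 to compound 4 (0.24 log units; within the scatter), with a wide range. Compound 4 is estimated at 30000 nM, between 5000 nM and 150000 nM.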

Compound 4, half-maximal inhibitory concentration: 229 nM
Estimate against measurement, compound 4: 130-fold (2.12 log units) above; measured number outside the range, below it.
By their numbers in this assay, from the lowest: compound 4; then compound 2; then compound 3; then compound 1.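

Configuration at the stereocentre on the saturated chain carbon proves to be a strong control on this number, a dimension that compounds 1, 2 and 3 could not reveal, since all are drawn R and differ only in the amino substituent. In this assay, drawing this centre S instead of R gives a 230-fold lower number from compound 1 to compound 4 (2.36 log units; beyond the scatter). The shift can be assigned to configuration alone because nothing else separates the pair: the fact that compounds 1 and 4 differ only in the configuration as drawn.

The compounds shown leave open whether S gives a similar shift with methylamino or isopropylamino on the shared core. They also leave open how a longer chain at the stereocentre would behave.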